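Swapping a pyridine for a trifluoromethylphenyl: cytotoxicity outlook

The compounds below may be only part of what the source reports. "The series", "measured", "known", "first", "only" and "open" are said of these compounds alone.

Compound 1 `CC(=O)N1CCC(C(=O)N(CCCN2CCN(Cc3ccncc3)CC2)c2ccc(C)c(Cl)c2)CC1` carries a pyridin-4-yl group on a saturated chain carbon bound to an amine nitrogen in a ring. In an ADME assay (Homo sapiens) for cytotoxicity (a lower number here means that less compound is tolerated, a higher number that more compound is tolerated), compound 1 gives only a limit, > 56700 nM, which is the limit of > 56700 nM in this assay, at which 1 of the 3 values shown sits. Compound 2 `CC(=O)N1CCC(C(=O)N(CCCN2CCC(CNc3ncccn3)CC2)c2ccc(C)c(Cl)c2)CC1` likewise gives only a limit in this assay, > 55100 nM, which is the limit of > 55100 nM in this assay, at which 1 of the 3 values shown sits. Compound 3 `CCN(Cc1ccccc1)C(=O)C1CCN(CCCN(C(=O)C2CCN(C(C)=O)CC2)c2ccc(C)c(Cl)c2)CC1` gives a number in this assay, 83.9 nM, and the step of an at least 650-fold lower number from compound 2 to compound 3 (2.81 log units; beyond the scatter) shows that one change at a ring position can move the read-out a long way. Compound 4 `CC(=O)N1CCC(C(=O)N(CCCN2CCN(Cc3ccc(C(F)(F)F)cc3)CC2)c2ccc(C)c(Cl)c2)CC1` differs from compound 1 by 4-(trifluoromethyl)phenyl in place of pyridin-4-yl on a saturated chain carbon bound to an amine nitrogen in a ring. Among the measured compounds shown here, no measured step matches this change directly, so the one large step between compound 2 and compound 3 serves only as a warning that the read-out can fall sharply. Compound 4 is therefore expected to sit somewhat lower than compound 1, with the step of an at least 1.8-fold lower number from compound 1 to compound 4 (0.27 log units; that floor lies within the scatter) estimated, and its estimate in this assay is 30000 nM, in the range 8000 nM to 60000 nM.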

Compound 4, half-maximal cytotoxic concentration: 30500 nM
Compound 4: the middle estimate sits 1.0-fold (0.01 log units) below what was measured, within the range that was stated.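

Compound 4 turns this position from a limit into a number, so the change can now be read in this assay with a real value on one side: an at least 1.8-fold lower number from compound 1 to compound 4 (0.26 log units; that floor lies within the scatter). That floor alone does not establish a fall, and the true gap could be small or much larger. The size of the step stays open because compound 1 gives only a limit: the limit of > 56700 nM in this assay, at which 1 of the 4 values shown sits.

The change swaps two things at once, removing the ring nitrogen and adding the trifluoromethyl group, and the compounds shown cannot tell which of the two matters. A plain benzyl group at the same place would separate them, and a 4-chlorobenzyl or 4-methoxybenzyl group would show whether the read-out depends on what sits on the ring.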